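The compounds below may be only part of what the source reports. "The series", "measured", "known", "first", "only" and "open" are said of these compounds alone.

In a functional assay on CHO cells for agonist activity at Alpha-1A adrenergic receptor (Homo sapiens), read by FLIPR and calcium flux (on this read-out lower numbers stand for an effect already at smaller amounts and higher numbers for an effect only at larger amounts of compound), compound 1 `c1cc(-c2nccs2)c2c(c1)C(c1ncc[nH]1)CC2` gives 426 nM, the highest of the three numbers measured here. Compound 3 `Cc1ccc2c(c1NS(C)(=O)=O)CCC2c1ncc[nH]1` gives 33 nM and compound 2 `Cc1c(OCC2=NCCN2)ccc(Cl)c1NS(C)(=O)=O` gives 25 nM; both of these lie well below compound 1, beyond the usual scatter. Compound 4 `c1ccc2c(c1)CCC2c1ncc[nH]1` has not yet been measured. It differs from compound 1 in a single place: hydrogen in place of 1,3-thiazol-2-yl on an aromatic carbon Compound 4 is thus the shared core without the 1,3-thiazol-2-yl group. Among the compounds with values here, no measured pair of compounds shows this change on its own, so its effect is unknown. Only a small step is expected, a 1.4-fold lower number from compound 1 to compound 4 (0.15 log units; within the scatter), with the direction uncertain. Compound 4 is therefore estimated at 300 nM, within a range from 60 nM to 1500 nM.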

Compound 4, half-maximal effective concentration: 473 nM
For compound 4 the middle estimate is 1.6-fold (0.20 log units) below the measured one; low and high end bracket the measured number.
By their numbers in this assay, from the lowest: compounds 2 and 3 (each within the scatter of the next); then compounds 1 and 4 (each within the scatter of the next).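

Within this assay the swap of 1,3-thiazol-2-yl for hydrogen on this aromatic carbon gives a 1.1-fold higher number from compound 1 to compound 4 (0.05 log units; within the scatter) and so does not separate the two compounds. At this position, then, the 1,3-thiazol-2-yl group and its five heavy atoms leave no measurable mark on this read-out. Nothing at hand explains this result. Still open, going by these compounds, is whether another group on the same aromatic carbon, such as an amine or a carboxylic acid, would leave the number just as it is. A single pair also cannot show whether this holds on any other core.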